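Phenyl for isobutyl on a carbamate selenocyanate

A few compounds are considered here, and "the series" means these few. Any claim that something is new, unique, unknown or untested is made for them only; others in the source may bear on it.

Measured so far:
compound 1, `CCOC(=O)Nc1ccc([Se][Se]c2ccc(NC(=O)OCC)cc2)cc1`, 28800 nM;
compound 2, `CC(C)COC(=O)Nc1ccc([Se]C#N)cc1`, 21600 nM;
compound 3, `Cc1ccc(OC(=O)Nc2ccc([Se][Se]c3ccc(NC(=O)Oc4ccc(C)cc4)cc3)cc2)cc1`, 4400 nM.

These numbers come from a functional assay on PC-3 cells (Homo sapiens) for cytotoxicity, read by MTT assay, with a stated time of 72 h; a lower number here means a stronger inhibitor of growth, a higher number a weaker inhibitor of growth. Compound 2 sits near the top of the three, close to compound 1, the two lying within the usual scatter of each other, while compound 3 gives a number well below that of compound 2. Compound 4, `N#C[Se]c1ccc(NC(=O)Oc2ccccc2)cc1`, has not been measured. It differs from compound 2 by phenyl in place of isobutyl on an oxygen next to a carbonyl group. For the measured compounds named here, no directly comparable step has been measured, so the size of the step is uncertain. Compound 4 is expected to give a lower number than compound 2, a step of a 2.7-fold lower number from compound 2 to compound 4 (0.43 log units; beyond the scatter) in this assay, because compound 3 gives 4400 nM while compound 1 gives 28800 nM. The estimate for compound 4 is 8000 nM, with a range from 3000 nM to 25000 nM.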

Compound 4, concentration for 50% growth inhibition: 9100 nM
Compound 4: the middle estimate sits 1.1-fold (0.06 log units) below what was measured, within the range that was stated.
By their numbers in this assay, from the lowest: compound 3; then compound 4; then compounds 2 and 1 (each within the scatter of the next).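

Before compound 4, no two compounds differed in only one place, so this is the first direct reading of a change on the oxygen next to a carbonyl group. With everything else held the same, phenyl in place of isobutyl gives a 2.4-fold lower number from compound 2 to compound 4 (0.38 log units; beyond the scatter) in this assay, a modest step that lies beyond the scatter. Nothing available explains why the number falls.

A single step cannot show whether the ring itself matters or only the larger group. Going by these compounds, what a benzyl group or a longer chain would give on this oxygen remains open.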